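Removing the Aminoalkyl Chain from an Indolocarbazole-type Core

This account rests on a few compounds, and the source may have more. Where it says the series, first, only, none or still open, it means among the compounds named here.

The shared core carries, in compound 2 `CN1CCN(CCCCn2c3c(c4ccccc42)C(=O)c2c[n+]([O-])c4ccccc4c2C3=O)CC1`, a 4-(4-methylpiperazin-1-yl)butyl chain on the aromatic nitrogen. In a functional assay on A549 cells (Homo sapiens) for cytotoxicity, read by MTT assay, with a stated time of 72 h (a lower number here means a stronger inhibitor, a higher number a weaker inhibitor), compound 2 gives 90 nM, close to compound 1 `CC1(C)OCC(Cn2cc(Cn3c4c(c5ccccc53)C(=O)c3c[n+]([O-])c5ccccc5c3C4=O)nn2)O1` with 80 nM, while compound 3 `CCCN1CCN(CCCCn2c3c(c4ccccc42)C(=O)c2c[n+]([O-])c4ccccc4c2C3=O)CC1` gives 320 nM, so that a 3.6-fold higher number from compound 2 to compound 3 (0.55 log units; beyond the scatter). Compound 4 `O=C1c2c[n+]([O-])c3ccccc3c2C(=O)c2[nH]c3ccccc3c21` differs from compound 2 as follows: hydrogen in place of 4-(4-methylpiperazin-1-yl)butyl on an aromatic nitrogen. Among the measured compounds shown here, no measured step bears directly on losing the whole chain; the step from compound 2 to compound 3 only shows that changes at the chain's end shift the number modestly. The unsubstituted compound 4 is therefore estimated at 250 nM, in a range from 50 nM to 1500 nM, that is, an expected step of a 2.8-fold higher number from compound 2 to compound 4 (0.44 log units; beyond the scatter).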

Compound 4, half-maximal inhibitory concentration: 320 nM
The estimate for compound 4 lay 1.3-fold (0.11 log units) below the measured number; the measured number falls inside the stated range.
By their numbers in this assay, from the lowest: compounds 1 and 2 (each within the scatter of the next); then compounds 3 and 4 (each within the scatter of the next).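

In this assay, removing the entire chain from the aromatic nitrogen gives a 3.6-fold higher number from compound 2 to compound 4 (0.55 log units; beyond the scatter). The earlier compounds shown here varied only the end of the chain, whereas this step shows that the shared core with hydrogen on that nitrogen still gives a nanomolar number, so the full 4-(4-methylpiperazin-1-yl)butyl chain is not needed for that. Nothing available explains the step. As far as these compounds go, it remains open how a shorter chain, or a chain ending in a morpholine or a carboxylic acid, would behave at this nitrogen.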